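A Double Bond in the Chain of Compound 2

This account rests on a few compounds, and the source may have more. Where it says the series, first, only, none or still open, it means among the compounds named here.

In a functional assay on HeLa cells (Homo sapiens) for antiproliferative activity, read by MTT assay, with a stated time of 48 h (a lower number here means a stronger inhibitor, a higher number a weaker inhibitor), compound 1 `COc1cc(CNC(=O)CCCCCCC(C)C)ccc1OC(=O)CCC(=O)Oc1ccc(-c2cc(=S)ss2)cc1` gives 5530 nM, a measured number. Compound 2 `COc1cc(CNC(=O)CCCCCCC(C)C)ccc1OC(=O)c1ccc(C(N)=S)cc1` gives > 50000 nM, which is a limit of the assay and not a number. The two compounds differ in more than one place, so their values cannot be read as the effect of a single change.

Compound 3 `COc1cc(CNC(=O)CCCC/C=C/C(C)C)ccc1OC(=O)c1ccc(C(N)=S)cc1` departs from compound 2 in one place, where 3-methylbut-1-en-1-yl stands in place of isopentyl on a saturated chain carbon, four bonds along the chain from a carbonyl carbon (3-methylbut-1-en-1-yl in place of isopentyl on a saturated chain carbon, four bonds along the chain from a carbonyl carbon). The entering group brings one double bond outside aromatic rings, and its heavy-atom count matches that of the group it replaces.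

Going by the values given here, no measured pair of compounds shows what this change does, so the expectation starts from where compound 2 stands. The estimated step, an at least 1.1-fold lower number from compound 2 to compound 3 (0.04 log units; that floor lies within the scatter), is expected to stay within the usual scatter, in neither direction. Compound 3 may well return only a limit in this assay. The estimate for compound 3 is 45000 nM, with an expected range from 20000 nM to 100000 nM.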

Compound 3, half-maximal inhibitory concentration: 39600 nM
Beside the measured number, compound 3's estimate is 1.1-fold (0.06 log units) above it; measured number inside the range.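

In this assay compound 3 gives 39600 nM, a measured number, so a chain carrying 3-methylbut-1-en-1-yl at this place, on a saturated chain carbon four bonds along the chain from a carbonyl carbon, yields a value that can be compared directly. Compound 2 gives > 50000 nM, which is a limit of the assay and not a number. Swapping isopentyl for 3-methylbut-1-en-1-yl, a change of one double bond with the same count of heavy atoms, gives an at least 1.2-fold lower number from compound 2 to compound 3 (0.10 log units; that floor lies within the scatter), and this step is known only as a floor, with its true size unsettled, because one end of the comparison is not a number: the limit of > 50000 nM in this assay, at which 1 of the 3 values shown sits.

The compounds shown leave open what a cis double bond at the same place, a longer chain or a phenyl ring in place of the 3-methylbut-1-en-1-yl group would do to the value. They also leave open what the same double bond would do in the chain of compound 1, which has a measured value of 5530 nM and differs from compound 2 in more than one place.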